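A further acyl group on compound 2

A few compounds are considered here, and "the series" means these few. Any claim that something is new, unique, unknown or untested is made for them only; others in the source may bear on it.

Measured so far in a functional assay on ZR-75-1 cells (Homo sapiens) for inhibition, read by MTT assay, with a stated time of 24 h (on this read-out higher numbers stand for weaker inhibition of growth and lower numbers for stronger inhibition of growth), as follows:
Compound 1 (`N[C@@H](CCC(=O)OC[C@H]1O[C@@H](n2cc(F)c(=O)[nH]c2=O)C[C@@H]1OC(=O)CC[C@H](N)C(=O)O)C(=O)O`): 3100000 nM
Compound 2 (`N[C@@H](CC(=O)OC[C@H]1O[C@@H](n2cc(F)c(=O)[nH]c2=O)C[C@@H]1O)C(=O)O`): 3900000 nM

The values of compound 2 and compound 1 lie within the usual scatter of each other, so these measurements do not separate them. Compound 3 (`N[C@@H](CC(=O)OC[C@H]1O[C@@H](n2cc(F)c(=O)[nH]c2=O)C[C@@H]1OC(=O)C[C@H](N)C(=O)O)C(=O)O`) keeps compound 2 intact except for one change, with (2-amino-2-carboxyethyl)carbonyl in place of hydrogen on an oxygen on a saturated carbon. Among the measured compounds shown here, no measured pair isolates this change. The nearest guide is compound 1, which also carries an acyl group on that oxygen and gives 3100000 nM within the scatter of compound 2. In this assay no shift beyond the scatter is therefore expected, and the estimated 1.2-fold lower number from compound 2 to compound 3 (0.07 log units; within the scatter) remains small in either direction. Compound 3 is expected at 3300000 nM with an estimated range from 1700000 nM to 6500000 nM when it is measured.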

Compound 3, concentration for 50% growth inhibition: 1900000 nM
Compound 3: middle estimate off by 1.7-fold (0.24 log units), on the high side; the range from low to high includes it.
By their numbers in this assay, from the lowest: compounds 3, 1 and 2 (each within the scatter of the next, the first and the last beyond it).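

In this assay, (2-amino-2-carboxyethyl)carbonyl in place of hydrogen on this oxygen gives a 2.1-fold lower number from compound 2 to compound 3 (0.31 log units; beyond the scatter), the first single change shown at this position to lie beyond the scatter, though only modestly. The free hydroxy is therefore not needed for the growth inhibition seen on these cells, since compound 3 carries the acyl group there and inhibits growth more strongly than compound 2. Nothing measured here accounts for this shift.

On these data alone, whether a plain acetyl group on this oxygen would do the same, or whether the amine or the carboxylic acid of the new group matters, stays open. As far as these compounds go, it is also open whether a longer chain between the ester carbonyl and the amino acid end would move the number further in either direction.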